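Chain extension in the diaryl urea series: tridecyl to tetradecyl

The compounds below may be only part of what the source reports. "The series", "measured", "known", "first", "only" and "open" are said of these compounds alone.

Within the data shown here, compound 2 `CCCCCCCCCCCCCN1NN=C(NC(=O)Nc2c(C(C)C)cccc2C(C)C)N1` gives 9 nM in an assay on microsomes from intestine for inhibition of acyl-CoA:cholesterol acyltransferase (Oryctolagus cuniculus) (a lower number here means a stronger inhibitor, a higher number a weaker inhibitor), and holds the lowest number of the two compounds measured so far. Compound 1 `CCCCN1NN=C(NC(=O)Nc2c(C(C)C)cccc2C(C)C)N1` gives 92 nM in this assay; the step between them is a 10-fold lower number from compound 1 to compound 2 (1.01 log units; beyond the scatter). Compound 3 `CCCCCCCCCCCCCCN1NN=C(NC(=O)Nc2c(C(C)C)cccc2C(C)C)N1` differs from compound 2 by methyl in place of hydrogen on a saturated chain carbon, ten or more bonds along the chain from an amine nitrogen in a ring. Among the measured compounds shown here, only one measured step bears on this change, namely a 10-fold lower number from compound 1 to compound 2 (1.01 log units; beyond the scatter), which extended the same chain by much more than a methyl and lowered the number clearly. Two points do not show whether one further methyl on an already long chain continues that trend; the expected effect is small, most likely within the scatter, with any direction toward a lower number. For compound 3 the expected result in this assay is 8 nM, with a range from 4 nM to 16 nM. The expected step of a 1.1-fold lower number from compound 2 to compound 3 (0.05 log units; within the scatter) is estimated to stay within the scatter.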

Compound 3, half-maximal inhibitory concentration: 12 nM
The estimate for compound 3 lay 1.5-fold (0.18 log units) below the measured number; the range from low to high includes it.
By their numbers in this assay, from the lowest: compounds 2 and 3 (each within the scatter of the next); then compound 1.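

In this assay, methyl in place of hydrogen on a saturated chain carbon, ten or more bonds along the chain from an amine nitrogen in a ring, gives a 1.3-fold higher number from compound 2 to compound 3 (0.12 log units; within the scatter), so compound 2 and compound 3 cannot be told apart at this chain length. The advantage of the long chain over the short one remains with this added methyl, as a 7.7-fold lower number from compound 1 to compound 3 (0.88 log units; beyond the scatter) shows. No measured property of these compounds bears on this result.

The compounds shown leave open how the number behaves at chain lengths between those of compound 1 and compound 2. They also leave open whether a longer chain, or a chain ending in a carboxylic acid or an amine, would keep a number in this range.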